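The source may hold more compounds than are shown below. What is called first, only, known or untested is meant among the compounds shown, and "the series" means these compounds.

Measured compounds:
compound 1 `Nc1cc(N)c2nc(-c3ccccc3)c(NCc3ccc(Cl)c(Cl)c3)nc2c1` — 5890 nM
compound 2 `CCOC(=O)[C@H](CCC(=O)O)NC(=O)c1ccc(Sc2nc3cc(N)cc(N)c3nc2-c2ccccc2)cc1` — < 100000 nM
compound 3 `COc1cc(CNc2nc3cc(N)cc(N)c3nc2-c2ccccc2)cc(OC)c1OC` — < 50200 nM

In a functional assay on IGROV-1 cells (Homo sapiens) for inhibition, read by sulforhodamine B assay, with a stated time of 48 h (on this read-out higher numbers stand for weaker inhibition of growth and lower numbers for stronger inhibition of growth), compound 1 gives 5890 nM. Compound 2 is reported only as a limit of this assay, < 100000 nM. Compound 3 likewise is reported only as a limit, < 50200 nM. Among the measured compounds shown here, compound 1 therefore stands as the sole compound of the three with a number in this assay; of the other two, one sits at the limit of < 100000 nM in this assay, at which 1 of the 3 values shown sits, and one at the limit of < 50200 nM in this assay, at which 1 of the 3 values shown sits, so no step between measured compounds can be stated.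

Compound 4 `Nc1cc(N)c2nc(-c3ccccc3)c(NCc3ccc(F)cc3)nc2c1` has not yet been measured. It differs from compound 1 in one place: 4-fluorophenyl in place of 3,4-dichlorophenyl on a saturated chain carbon bound to a nitrogen on an aromatic ring. For the measured compounds named here, no measured pair shows this change, so the expectation rests on compound 1 alone and on the size of the change. The step from compound 1 to compound 4 is expected to be a 2.5-fold higher number from compound 1 to compound 4 (0.41 log units; beyond the scatter), toward weaker inhibition of growth and somewhat beyond the scatter. Compound 4 is thus expected to give about 15000 nM, within a range from 5000 nM to 50000 nM.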

Compound 4, concentration for total growth inhibition: < 100000 nM
Compound 4: no number, only a limit (the forecaster's own chance of this, stated with the estimate: 25%); the middle value does not contradict the limit.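

In this assay, among the compounds shown here, compound 4 is reported only as a limit, < 100000 nM, so no step from compound 1 to compound 4 can be read. The compounds shown leave open how far, and in which direction, 4-fluorobenzyl in place of 3,4-dichlorobenzyl shifts growth inhibition.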